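Ring-opened analogue of compound 1: working expectation

The compounds below may be only part of what the source reports. "The series", "measured", "known", "first", "only" and "open" are said of these compounds alone.

The three measured compounds share the core seen in compound 1 `C=C1CC[C@H]2C(C)(C)CCC[C@]2(C)[C@H]1CCC1=CC(=O)OC1`. In a functional assay on RAW264.7 cells (Mus musculus) for inhibition, with a stated time of 24 h (on this read-out higher numbers stand for weaker inhibition and lower numbers for stronger inhibition), compound 1 gives 18800 nM, the lowest of the three numbers, though within the scatter of both others: compound 3 `C=C1CC[C@H]2C(C)(C)CCC[C@]2(C)[C@H]1CCC1=CC(O)OC1=O` gives 25800 nM and compound 2 `C=C1CC[C@H]2C(C)(C)CCC[C@]2(C)[C@H]1C/C=C1\CC(OCC)OC1=O` gives 31200 nM. Among the measured compounds shown here, the only single-site step, a 1.4-fold higher number from compound 1 to compound 3 (0.14 log units; within the scatter), also exchanges the group on the saturated chain carbon and stayed within the scatter. Compound 4 `C=C1CC[C@H]2C(C)(C)CCC[C@]2(C)[C@H]1C/C=C(/C=O)CO` differs from compound 1 by a group of 6 heavy atoms (4 carbon, 2 oxygen; no ring) in place of a group of 7 heavy atoms (5 carbon, 2 oxygen; one five-membered non-aromatic ring with 1 hetero atom), on a saturated chain carbon bound to a saturated ring carbon. For the measured compounds named here, no measured step removes a ring, so the guide is weak. The expected step is a 1.3-fold higher number from compound 1 to compound 4 (0.11 log units; within the scatter), not beyond the scatter. For compound 4 the estimated value is 24000 nM, with a range from 8000 nM to 75000 nM.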

Compound 4, half-maximal inhibitory concentration: 28700 nM
Beside the measured number, compound 4's estimate is 1.2-fold (0.08 log units) below it; measured number inside the range.
By their numbers in this assay, from the lowest: compounds 1, 3, 4 and 2 (each within the scatter of the next).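

In this assay, a group with no ring in place of the group with one five-membered non-aromatic ring, on a saturated chain carbon bound to a saturated ring carbon, gives a 1.5-fold higher number from compound 1 to compound 4 (0.18 log units; within the scatter). At this place, then, the ring is not required to keep the number at this level, and the change in hydrogen-bond donor count brings no shift beyond the scatter. No evidence on the cause is available.

On these data alone, whether any group at this place can move the number beyond the scatter remains open. As far as these compounds go, the effect of a carboxylic acid or an amine on the open chain also remains unknown.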